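Replacing a chloro-pyrrolopyridine with a pyrrolopyrimidinone at the chain end

This account rests on a few compounds, and the source may have more. Where it says the series, first, only, none or still open, it means among the compounds named here.

Compound 1 `O=C1NC(O)(CCn2cnc3ccnc(Cl)c32)C(OCc2ccccc2)=C1OCc1ccccc1`: "not determined" (no result reported)
Compound 2 `O=C1O/C(=C\Cn2cnc3c(F)nc(F)c(Cl)c32)C(OCc2ccccc2)=C1OCc1ccccc1`: "not determined" (no result reported)
Compound 3 `O=C1NC(O)(CCn2cnc3ccn(CCC4(O)NC(=O)C(OCc5ccccc5)=C4OCc4ccccc4)c3c2=O)C(OCc2ccccc2)=C1OCc1ccccc1`: 4400 nM; 7600 nM (2 entries)

In a functional assay on L1210/0 cells (Mus musculus) for antiproliferative activity, read by MTT assay, with a stated time of 72 h (on this read-out lower numbers stand for stronger inhibition and higher numbers for weaker inhibition), compound 1 gives "not determined" (no result reported), so it stands without a number of its own. Compound 2 likewise gives "not determined" (no result reported) there. Going by the values given here, the only compound with a result is compound 3, which in this assay gives 4400 nM; 7600 nM (2 entries); its two entries lie within the scatter of each other (the several entries of compound 3 in this assay, 4400 nM; 7600 nM (2 entries)).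

Compound 4 `O=C1NC(O)(CCn2cnc3cc[nH]c3c2=O)C(OCc2ccccc2)=C1OCc1ccccc1` arises from compound 1 through the change (a group of 10 heavy atoms (6 carbon, 3 nitrogen, 1 oxygen; one five-membered aromatic ring with 1 hetero atom, one six-membered aromatic ring with 2 hetero atoms) in place of a group of 10 heavy atoms (6 carbon, 3 nitrogen, 1 chlorine; one five-membered aromatic ring with 2 hetero atoms, one six-membered aromatic ring with 1 hetero atom), on a saturated chain carbon, two bonds along the chain from a saturated ring carbon). Among the compounds with values here, no measured pair shows a step of this kind, so compound 1 offers no number from which to reckon a direction in this assay. What compound 3 shows, 4400 nM; 7600 nM (2 entries), is the only anchor, and compound 4 carries one of the two arms that compound 3 carries twice. On that footing compound 4 is expected to give roughly 8000 nM, with a range from 2000 nM to 40000 nM, and the expected step from compound 1 cannot be sized at all.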

Compound 4, half-maximal inhibitory concentration: 107000 nM
Compound 4: the middle estimate sits 13-fold (1.13 log units) below what was measured; measured number above the stated range.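

In this assay, going by these compounds alone, compound 1 stands at "not determined" (no result reported), so no step from compound 1 to compound 4 can be read. The compounds shown leave open how the group entering in compound 4 compares on this read-out with the group it replaces in compound 1.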